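From isopropoxy to isopropyl: compound 1 and compound 4

The source may report more compounds than this note shows. Statements on the series, on what has been measured and on what is new or still open speak of the compounds shown alone.

Compound 1 `CCc1cc(CN2CC(C(=O)O)C2)sc1-c1ncc(-c2ccc(OC(C)C)c(C)c2)s1`: 0.07 mg/kg
Compound 2 `CCc1cc(CN2CC(C(=O)O)C2)sc1-c1ncc(-c2ccc(OC(C)C)c(C(C)C)c2)s1`: 0.53 mg/kg
Compound 3 `CCc1cc(CN2CC(C(=O)O)C2)sc1-c1ncc(-c2ccc(OC(C)C)c(F)c2)s1`: 0.48 mg/kg

In a functional assay on the whole organism (spleen, spleen, strain LEW) for inhibition, with Rattus norvegicus as the target, with a stated time of 4 days (on this read-out lower numbers stand for an effect already at smaller amounts and higher numbers for an effect only at larger amounts of compound), compound 1 has the lowest of the three numbers, and its gaps to both others lie beyond the scatter. Compound 4 `CCc1cc(CN2CC(C(=O)O)C2)sc1-c1ncc(-c2ccc(C(C)C)c(C)c2)s1` has not yet been measured. It keeps the core of compound 1 and differs in one group: isopropyl in place of isopropoxy on an aromatic carbon. This puts isopropyl in place of isopropoxy on an aromatic carbon, ortho to a methyl group.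

For the measured compounds named here, no measured step touches the isopropoxy group itself, so the evidence is indirect. The closest evidence comes from changes to that methyl group: a 7.6-fold higher number from compound 1 to compound 2 (0.88 log units; beyond the scatter), and a 6.9-fold higher number from compound 1 to compound 3 (0.84 log units; beyond the scatter). Between the two replacements there is a 1.1-fold lower number from compound 2 to compound 3 (0.04 log units; within the scatter). Both departures from compound 1 on this six-membered aromatic ring thus gave higher numbers, though neither shows how the isopropoxy group would respond.

A step in the same direction is therefore expected, probably somewhat smaller and with a wide margin. The expected step in this assay is a 2.9-fold higher number from compound 1 to compound 4 (0.46 log units; beyond the scatter). For compound 4 the estimated value is 0.2 mg/kg, with an expected range from 0.05 mg/kg to 0.8 mg/kg.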

Compound 4, dose for 50% inhibition: 1.07 mg/kg
Compound 4: middle estimate off by 5.4-fold (0.73 log units), on the low side, and the stated range ends below it.
By their numbers in this assay, from the lowest: compound 1; then compounds 3 and 2 (each within the scatter of the next); then compound 4.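

Replacing the isopropoxy group of compound 1 with isopropyl gives a 15-fold higher number from compound 1 to compound 4 (1.18 log units; beyond the scatter) in this assay, a large step, whereas the two changes to the neighbouring methyl group, a 7.6-fold higher number from compound 1 to compound 2 (0.88 log units; beyond the scatter) and a 6.9-fold higher number from compound 1 to compound 3 (0.84 log units; beyond the scatter), were modest. For the compounds shown here, this is the first direct look at the isopropoxy position, and it shows that the read-out responds strongly there: the change removes the oxygen atom, the one hydrogen-bond acceptor counted in the group, yet leaves its carbons in place, so keeping those carbons was not enough to hold the low number of compound 1. Nothing in the information available explains why this exchange has such an effect.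

On these data alone, whether a methoxy group, a longer ether chain, a hydroxyl or an amine at this place would keep the low number of compound 1 remains open. Also open, as far as these compounds go, is whether losing the oxygen would cost as much with fluoro or isopropyl in place of the methyl group.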